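The compounds below may be only part of what the source reports. "The series", "measured", "known", "first", "only" and "open" are said of these compounds alone.

Measured so far:
compound 1 `COc1ccc(C(=O)Nc2ccccc2Br)cc1OC1CCCC1`: 130 nM
compound 2 `COc1ccc(C(=O)Nc2c(F)cccc2F)cc1OC1CCCC1`: 70 nM
compound 3 `COc1ccc(C(=O)Nc2ccccc2SC)cc1OC1CCCC1`: 1200 nM

In an assay on isolated protein for inhibition of phosphodiesterase 4A (Sus scrofa) (on this read-out lower numbers stand for stronger inhibition and higher numbers for weaker inhibition), compound 2 gives 70 nM; compound 1 lies within the scatter of it (a 1.9-fold lower number from compound 1 to compound 2 (0.27 log units; within the scatter)), and compound 3 lies beyond it (a 17-fold higher number from compound 2 to compound 3 (1.23 log units; beyond the scatter)). Compound 4 `COc1ccc(C(=O)Nc2c(F)cccc2F)cc1OC` differs from compound 2 by methyl in place of cyclopentyl on an oxygen on an aromatic ring. Every measured step changes the group on the amide-type nitrogen, so none of them covers a change at this oxygen, and the expectation for compound 4 rests on compound 2 alone and carries a wide range. For compound 4 the estimate in this assay is 1500 nM, between 150 nM and 15000 nM. For the measured compounds named here, that estimate amounts to an expected step of a 21-fold higher number from compound 2 to compound 4 (1.33 log units; beyond the scatter), which no measured pair supports or contradicts.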

Compound 4, half-maximal inhibitory concentration: 900 nM
Estimate against measurement, compound 4: 1.7-fold (0.22 log units) above; measured number inside the range.
By their numbers in this assay, from the lowest: compounds 2 and 1 (each within the scatter of the next); then compounds 4 and 3 (each within the scatter of the next).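

For the compounds shown here, replacing cyclopentyloxy with methoxy gives the first measured change at this oxygen, and in this assay inhibition weakens by a large step, a 13-fold higher number from compound 2 to compound 4 (1.11 log units; beyond the scatter). The group on this oxygen therefore matters, not only the group on the amide-type nitrogen. Nothing available explains why the change has this effect. Open questions are whether a cyclohexyl ring or an open chain such as butyl on this oxygen would keep the value of compound 2 and whether a ring is needed at all. The same change also remains to be seen alongside 2-bromophenyl on the amide-type nitrogen.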